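A few compounds are considered here, and "the series" means these few. Any claim that something is new, unique, unknown or untested is made for them only; others in the source may bear on it.

Two compounds share a common core and differ only in the aryl group on a saturated ring carbon. Compound 1 `Cc1cc(O)c(C2=NN(c3ccc(S(N)(=O)=O)cc3)C(c3ccccc3Cl)C2)cc1Cl` carries a 2-chlorophenyl there, and in a functional assay on PC-3 cells (Homo sapiens) for antiproliferative activity, with a stated time of 48 h (a lower number here means that less compound is tolerated, a higher number that more compound is tolerated), compound 1 gives 6980 nM. Compound 2 `COc1ccc(C2CC(c3cc(Cl)c(C)cc3O)=NN2c2ccc(S(N)(=O)=O)cc2)cc1OC` carries a 3,4-dimethoxyphenyl in its place. In this assay compound 2 reaches only the limit of the assay, > 100000 nM, so no number is known for it. The step of an at least 14-fold higher number from compound 1 to compound 2 (1.15 log units; beyond the scatter) is therefore only a lower bound on the loss, as the limit of > 100000 nM in this assay, at which 1 of the 2 values shown sits, shows.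

Compound 3 `COc1ccc(C2CC(c3cc(Cl)c(C)cc3O)=NN2c2ccc(S(N)(=O)=O)cc2)c(OC)c1OC` is the next member of the series: methoxy in place of hydrogen on an aromatic carbon. Among the compounds with values here, only one measured step, from compound 1 to compound 2, bears on this change; it was large and pointed toward more compound being tolerated, and it says nothing about a further methoxy. Compound 2 stands at the assay limit. Compound 3 is accordingly expected to stay there as well, so that the expected step that the limit leaves unreadable from compound 2 to compound 3 cannot be told apart from the scatter. In this assay compound 3 is estimated at 150000 nM, with a range from 40000 nM to 500000 nM.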

Compound 3, concentration lethal to 50% of the cells: 40100 nM
Compound 3: middle estimate off by 3.7-fold (0.57 log units), on the high side; the range from low to high includes it.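

Within the data shown here, the result gives a first reading at this aromatic carbon, ortho to a large group and ortho to a methoxy group. In this assay, methoxy in place of hydrogen there brings an at least 2.4-fold lower number from compound 2 to compound 3 (0.39 log units; beyond the scatter), so the added methoxy moves the number down from the assay limit instead of leaving it there, and the true size of this step stays unknown because compound 2 has only a limit: the limit of > 100000 nM in this assay, at which 1 of the 3 values shown sits.

The 2,3,4-trimethoxyphenyl still does not match the 2-chlorophenyl on the saturated ring carbon, with a 5.7-fold higher number from compound 1 to compound 3 (0.76 log units; beyond the scatter) standing beyond the scatter, so the aryl group at that position continues to separate the compounds even after the extra methoxy.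

The compounds shown leave open whether a methoxy at this aromatic carbon would give a similar step without the other two methoxy groups, and whether a fluorine, a hydroxy or an amine there would move the number the same way. They also leave open whether a 2-methoxyphenyl on the saturated ring carbon would stand nearer to compound 1 or to compound 3.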